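The compounds below may be only part of what the source reports. "The series", "measured", "known", "first", "only" and "open" are said of these compounds alone.

Working notes on the series, read in a functional assay on HL-60 cells (Homo sapiens) for cytotoxicity, read by MTT assay, with a stated time of 3 days; on this read-out lower numbers stand for stronger inhibition and higher numbers for weaker inhibition. Three compounds on the shared core differ in one group: compound 1 `N#Cc1c(NN)nc(SCc2nc3ccccc3[nH]2)nc1-c1ccccc1` gives 11.9 nM, compound 2 `N#Cc1c(NC(N)=O)nc(SCc2nc3ccccc3[nH]2)nc1-c1ccccc1` gives 2.9 nM, and compound 3 `N#Cc1c(-c2ccccc2)nc(SCc2nc3ccccc3[nH]2)nc1N1CCNCC1` gives 4 nM. The step of a 1.4-fold higher number from compound 2 to compound 3 (0.14 log units; within the scatter) lies within the scatter, whereas a 3.0-fold lower number from compound 1 to compound 3 (0.47 log units; beyond the scatter) is modest but beyond it, as is a 4.1-fold lower number from compound 1 to compound 2 (0.61 log units; beyond the scatter). Compound 3 therefore sits with compound 2 at the low end of the numbers shown, apart from compound 1.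

Compound 4 `Cc1ccc(S(=O)(=O)N2CCN(c3nc(SCc4nc5ccccc5[nH]4)nc(-c4ccccc4)c3C#N)CC2)cc1` carries (4-methylphenyl)sulfonyl in place of hydrogen on an amine nitrogen in a ring of compound 3: (4-methylphenyl)sulfonyl in place of hydrogen on an amine nitrogen in a ring. Going by the values given here, no measured step changes this nitrogen, so the evidence is indirect. The nearest guide is the exchange of the whole group on the aromatic carbon, which stayed modest in a 3.0-fold lower number from compound 1 to compound 3 (0.47 log units; beyond the scatter). The added group is large and the data give no firm direction, so a modest move toward a higher number in this assay is only a cautious expectation. The estimated change is a 2.3-fold higher number from compound 3 to compound 4 (0.35 log units; beyond the scatter). For compound 4 the expected value is 9 nM, with an estimated range from 2 nM to 40 nM.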

Compound 4, half-maximal inhibitory concentration: 4.23 nM
Compound 4: the middle estimate sits 2.1-fold (0.33 log units) above what was measured; the range from low to high includes it.
By their numbers in this assay, from the lowest: compounds 2, 3 and 4 (each within the scatter of the next); then compound 1.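

In this assay, (4-methylphenyl)sulfonyl in place of hydrogen on the amine nitrogen in the ring gives a 1.1-fold higher number from compound 3 to compound 4 (0.02 log units; within the scatter), so the step lies within the scatter and the two compounds cannot be told apart on this read-out. Going by these compounds alone, this is the first direct reading at this nitrogen, as the earlier steps exchanged the whole group on the aromatic carbon, and it shows that a sulfonyl group of this size, with its carbon-only aromatic ring, can enter here without a step beyond the scatter. Nothing measured on these compounds explains why the number holds at this position.

Within the data shown here, with only one group on this nitrogen, the result sets no trend, and it remains open whether the same holds for a small methyl, an acetyl, a benzyl or a chain ending in a carboxylic acid. Going by these compounds, it also remains open what the sulfonyl linker and the methyl on the aromatic ring each contribute, which a plain phenylsulfonyl or a benzoyl on the same nitrogen could help to separate.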